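The source may report more compounds than this note shows. Statements on the series, on what has been measured and on what is new or still open speak of the compounds shown alone.

In a functional assay on A549 cells (Homo sapiens) for cytotoxicity, read by MTT assay, with a stated time of 72 h (a higher number here means a weaker inhibitor, a lower number a stronger inhibitor), compound 1 `O=C(Nc1nc2ccccc2s1)c1cn(-c2ccccc2)nc1-c1ccc(F)cc1` gives 9010 nM, and compound 2 `O=C(Nc1nc2ccccc2s1)c1cn(-c2ccccc2)nc1-c1ccc(Cl)cc1` gives 10300 nM. Going by the values given here, the one step between them, a 1.1-fold higher number from compound 1 to compound 2 (0.06 log units; within the scatter), swaps chloro for fluoro on an aromatic carbon, and it leaves the number where it was. Compound 2 thus has the higher of the two numbers, but compound 1 sits within the scatter of it, so no order between them can be read. Compound 3 `COc1ccc(-c2nn(-c3ccccc3)cc2C(=O)Nc2nc3ccccc3s2)cc1` differs from compound 2 by methoxy in place of chloro on an aromatic carbon. Among the compounds with values here, no measured step exchanges a halogen for methoxy at that position; the only step available, a 1.1-fold higher number from compound 1 to compound 2 (0.06 log units; within the scatter), changes a different group and was itself within the scatter, so it gives no direction. Compound 3 is therefore expected to show a step of a 1.1-fold lower number from compound 2 to compound 3 (0.06 log units; within the scatter) in this assay, nothing beyond the scatter. Compound 3 is estimated at 9000 nM, with a range from 3500 nM to 25000 nM.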

Compound 3, half-maximal inhibitory concentration: 13700 nM
Compound 3: the middle estimate sits 1.5-fold (0.18 log units) below what was measured, within the range that was stated.
By their numbers in this assay, from the lowest: compounds 1, 2 and 3 (each within the scatter of the next).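

In this assay, methoxy now joins chloro and fluoro on the aromatic carbon para to a large group, and both new steps, a 1.3-fold higher number from compound 2 to compound 3 (0.12 log units; within the scatter) and a 1.5-fold higher number from compound 1 to compound 3 (0.18 log units; within the scatter), stay within the scatter. The earlier compounds shown here showed only one halogen exchanged for another, whereas this change replaces a single chlorine or fluorine atom with a group that brings a carbon, an oxygen and a hydrogen-bond acceptor, and still no order among the three compounds can be read. Nothing available explains why this position shows so little response to the change.

On these data alone, whether an amine, a carboxylic acid or a longer chain at this position would move the number beyond the scatter remains open. Also open, as far as these compounds go, is how changes elsewhere on the shared core would read, since these three compounds differ at this one place only.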